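Swapping one nitrile for trifluoromethoxy on the phenyl ring

The compounds below may be only part of what the source reports. "The series", "measured", "known", "first", "only" and "open" are said of these compounds alone.

Measured compounds:
compound 1 `Cc1ccc2ccc(-c3cccc(Cl)c3)cc2n1` — 14000 nM
compound 2 `COc1ccccc1-c1ccc2ccc(C)nc2c1` — 4200 nM
compound 3 `Cc1ccc2ccc(-c3cc(C#N)cc(C#N)c3)cc2n1` — 2 nM

All three share the same core and differ only in the pendant phenyl ring. In a functional assay on CHO cells for inhibition of metabotropic glutamate receptor 5 (Rattus norvegicus), read by FLIPR and calcium flux (a higher number here means a weaker inhibitor, a lower number a stronger inhibitor), compound 3 gives the lowest number of the three, and its gaps to compound 2 and compound 1 both lie beyond the scatter, so compound 3 is the strongest inhibitor here. Compound 4 `Cc1ccc2ccc(-c3cc(C#N)cc(OC(F)(F)F)c3)cc2n1` has not yet been measured. It differs from compound 3 by trifluoromethoxy in place of cyano on an aromatic carbon. Among the measured compounds shown here, no measured pair shows this exact change, so its effect can only be estimated. Because compound 3 shows 2 nM with two cyano groups, and the compounds lacking cyano are far weaker, removing one is expected to cost potency by a 15-fold higher number from compound 3 to compound 4 (1.18 log units; beyond the scatter). Compound 4 is therefore expected near 30 nM, between 5 nM and 200 nM.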

Compound 4, half-maximal inhibitory concentration: 75 nM
Estimate against measurement, compound 4: 2.5-fold (0.40 log units) below, within the range that was stated.
By their numbers in this assay, from the lowest: compound 3; then compound 4; then compound 2; then compound 1.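

In this assay, among the compounds shown here, replacing one cyano group with trifluoromethoxy gives a 38-fold higher number from compound 3 to compound 4 (1.57 log units; beyond the scatter) and offers the first direct reading at this position: this swap costs a large part of the inhibition. Compound 4 still gives 75 nM with its remaining cyano group in place, so the change weakens inhibition without abolishing it. No measurement shown here accounts for the size of this loss.

As far as these compounds go, it remains open whether the loss comes from adding trifluoromethoxy or from giving up the second nitrile. A fluorine, a methyl group or an amine at this position could help separate the two.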